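Fluoro for methoxy in a weakly cytotoxic series

The compounds below may be only part of what the source reports. "The series", "measured", "known", "first", "only" and "open" are said of these compounds alone.

Measured in a functional assay on A549 cells (Homo sapiens) for cytotoxicity, read by WST assay, with a stated time of 48 h; a higher number here means a weaker inhibitor, a lower number a stronger inhibitor:
Compound 1 `N#C/C(=C\c1cn(Cc2ccc(Cl)cc2)c2ccccc12)C(=O)c1c[nH]c2cc(F)ccc12`: > 50000 nM (a limit)
Compound 2 `COc1ccc(Cn2cc(/C=C(\C#N)C(=O)c3c[nH]c4cc(OC)ccc34)c3ccccc32)cc1`: 28900 nM

Among the measured compounds shown here, compound 2 gives the only numeric reading, 28900 nM. Compound 1 reaches only a limit of the assay, > 50000 nM.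

Compound 3 `COc1ccc(Cn2cc(/C=C(\C#N)C(=O)c3c[nH]c4cc(F)ccc34)c3ccccc32)cc1` arises from compound 2 by fluoro in place of methoxy on an aromatic carbon, with fluoro in place of methoxy on an aromatic carbon. For the measured compounds named here, no measured pair isolates this change, so no step beyond the usual scatter is expected, with any drift towards weaker inhibition. Compound 1, which differs elsewhere too, already carries 6-fluoro-1H-indol-3-yl and shows > 50000 nM, a limit. The expected step of a 1.3-fold higher number from compound 2 to compound 3 (0.12 log units; within the scatter) is therefore modest. For compound 3 the estimate is 38000 nM, with an expected range of 17000 nM to 60000 nM.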

Compound 3, half-maximal inhibitory concentration: 36300 nM
The estimate for compound 3 lay 1.0-fold (0.02 log units) above the measured number; measured number inside the range.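

In this assay, fluoro in place of methoxy on this aromatic carbon gives a 1.3-fold higher number from compound 2 to compound 3 (0.10 log units; within the scatter), so 6-fluoro-1H-indol-3-yl and 6-methoxy-1H-indol-3-yl cannot be told apart in this series. Methoxy in place of chloro on an aromatic carbon gives an at least 1.3-fold lower number from compound 1 to compound 3 (0.13 log units; that floor lies within the scatter), a step that starts from a limit and so has no fixed size: the limit of > 50000 nM in this assay, at which 1 of the 3 values shown sits.

As far as these compounds go, whether an amine or a carboxylic acid on this aromatic carbon would move the number beyond the scatter remains open.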